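Indole series: amino-to-pyridinyl change at the benzo ring

A few compounds are considered here, and "the series" means these few. Any claim that something is new, unique, unknown or untested is made for them only; others in the source may bear on it.

Measured so far:
compound 1, `Brc1ccc2ccn(CCN3CCN4CCCC4C3)c2c1`: 72%
compound 2, `Brc1ccc2ccn(CCN3CCCN4CCCCC4C3)c2c1`: 99%
compound 3, `CN1CCCN(CCn2ccc3ccc(N)cc32)CC1`: 0%

In an assay on HEK293 cells for binding affinity to 5-hydroxytryptamine receptor 7 (Homo sapiens), read by radioligand binding, tested at 1 uM (on this read-out higher numbers stand for more inhibition at the one concentration tested (going by the name of the read-out) and lower numbers for less inhibition), compound 3 gives 0%, the lowest of the three numbers; compound 1 gives 72% and compound 2 gives 99%, both beyond the scatter above compound 3. Among the compounds with values here, compounds 1 and 2 differ from compound 3 in both the group on the benzo ring and the amine ring system, so no single step between measured compounds is available.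

Compound 4, `CN1CCCN(CCn2ccc3ccc(-c4cccnc4)cc32)CC1`, keeps the amine side of compound 3 and changes only the benzo ring: pyridin-3-yl in place of amino on an aromatic carbon. Since compound 3 gives 0% while, with a different group at that place, compound 1 gives 72% and compound 2 gives 99%, an upward step beyond the scatter is expected, though its size is uncertain. The estimated step of a number 40 percentage points higher from compound 3 to compound 4 (beyond the scatter) is therefore moderate. Compound 4 is expected to give 40% in this assay, within 5% to 85%.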

Compound 4, a percentage reported as inhibition, at one concentration (the size of the read-out at that concentration, not a potency): 35%
Compound 4: middle estimate off by 5 percentage points, on the high side; low and high end bracket the measured number.
By their numbers in this assay, from the lowest: compound 3; then compound 4; then compound 1; then compound 2.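

Within the data shown here, with the amine side held constant, pyridin-3-yl in place of amino on an aromatic carbon gives a number 35 percentage points higher from compound 3 to compound 4 (beyond the scatter) in this assay, the first single-change reading, and it shows that this position alone can move the number. The change swaps 1 hydrogen-bond donor for 0 and brings in one six-membered aromatic ring with 1 hetero atom, and the step alone does not separate these two differences. No supporting data bear on why the number rises.

Phenyl, with no ring nitrogen, or pyridin-4-yl at the same place would test whether the ring nitrogen and its location matter. Among these compounds, the effect of the amine ring system also remains open: compound 1 and compound 2 differ from compound 4 in more than one place, so no step to either can be read.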